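Swapping a Fluorophenyl for a Fluoropyridyl on Two Cores

A few compounds are considered here, and "the series" means these few. Any claim that something is new, unique, unknown or untested is made for them only; others in the source may bear on it.

Measured so far in a functional assay on CNE-2 cells (Homo sapiens) for antiproliferative activity, read by sulforhodamine B assay, with a stated time of 48 h; a higher number here means a weaker inhibitor, a lower number a stronger inhibitor:
compound 1 `COc1ccc(/C=C/C(=O)c2ccccc2-c2ccc(F)cc2)cc1` gives 53 nM
compound 2 `COc1ccc(/C=C/C(=O)c2ccccc2-c2ccc(F)nc2)cc1` gives 160 nM
compound 3 `O=C(/C=C/c1ccccc1-c1ccc(F)cc1)c1cccc(O)c1` gives 7300 nM

Compound 1 and compound 2 differ in one place, (6-fluoropyridin-3-yl in place of 4-fluorophenyl on an aromatic carbon), and this change made a 3.0-fold higher number from compound 1 to compound 2 (0.48 log units; beyond the scatter). Compound 3 has a different core; how its core differs from that of compound 1 is not broken down here, but its value in this assay stands far higher than that of either compound 1 or compound 2. Compound 4 `O=C(/C=C/c1ccccc1-c1ccc(F)nc1)c1cccc(O)c1` is not yet measured; it differs from compound 3 by 6-fluoropyridin-3-yl in place of 4-fluorophenyl on an aromatic carbon, the same change as seen between compound 1 and compound 2. Resting on that earlier step, compound 4 is expected to show a 3.0-fold higher number from compound 3 to compound 4 (0.48 log units; beyond the scatter) in this assay. The estimate for compound 4 is therefore 22000 nM, within 8000 nM to 60000 nM.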

Compound 4, half-maximal inhibitory concentration: 8700 nM
Estimate against measurement, compound 4: 2.5-fold (0.40 log units) above, and the stated range covers the measured number.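

In this assay, putting 6-fluoropyridin-3-yl in place of 4-fluorophenyl on the core of compound 3 gives a 1.2-fold higher number from compound 3 to compound 4 (0.08 log units; within the scatter). Set beside the earlier step, the results on the two cores cannot be told apart: the same change on two cores in this assay, a 3.0-fold higher number (0.48 log units; beyond the scatter) from compound 1 to compound 2 and a 1.2-fold higher number (0.08 log units; within the scatter) from compound 3 to compound 4, 2.5-fold (0.40 log units) apart, within the scatter of two such steps. The change therefore carries across these two cores without a clear difference in its size, but two pairs cannot show that the steps are truly equal or that the same would hold on a further core.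

The compounds shown leave open what an amine or a carboxylic acid would do in place of the fluorine on either core. They also leave open how this change behaves in any other assay.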